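From Compound 3 to Compound 4: Losing 3-carboxyazetidin-1-yl

The source may hold more compounds than are shown below. What is called first, only, known or untested is meant among the compounds shown, and "the series" means these compounds.

In a toxicity assay on Huh-7.5 cells (Homo sapiens) for inhibition, read by MTT assay, with a stated time of 96 h (a higher number here means that more compound is tolerated, a lower number that less compound is tolerated), compound 1 `CN(C)C1CCN(Cc2ccc(NC(=O)c3ccc(OCCCCl)c([N+](=O)[O-])c3)cc2C(F)(F)F)C1` gives 5800 nM and compound 2 `CN1CCN(Cc2ccc(NC(=O)c3ccc(OCCCl)c([N+](=O)[O-])c3)cc2C(F)(F)F)CC1` gives 9040 nM. Compound 3 `O=C(Nc1ccc(CN2CC(C(=O)O)C2)c(C(F)(F)F)c1)c1ccc(OCCCCl)c([N+](=O)[O-])c1` gives > 200000 nM, and this is a limit of the assay, not a number. Compound 3 therefore stands at the limit of > 200000 nM in this assay, at which 1 of the 3 values shown sits.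

Compound 4 `CC1CN(Cc2ccc(NC(=O)c3ccc(OCCCCl)c([N+](=O)[O-])c3)cc2C(F)(F)F)CC(C)O1` has not yet been measured. It carries 2,6-dimethylmorpholin-4-yl in place of 3-carboxyazetidin-1-yl on a saturated chain carbon bound to an aromatic carbon.

Among the compounds with values here, one measured step bears on this change. Putting 3-carboxyazetidin-1-yl in place of 3-(dimethylamino)pyrrolidin-1-yl at that same place gave an at least 34-fold higher number from compound 1 to compound 3 (1.53 log units; beyond the scatter), a large step beyond the usual scatter. Compound 4 gives up that same group, so a large step in the opposite direction, towards a lower number, is expected in this assay. Within the data shown here, no measured compound carries 2,6-dimethylmorpholin-4-yl, so the landing point remains uncertain, but the likeliest region is near compound 1 at 5800 nM and compound 2 at 9040 nM. The expected change is an at least 16-fold lower number from compound 3 to compound 4 (1.22 log units; beyond the scatter). For compound 4 the estimate is 12000 nM, with an expected range from 4000 nM to 40000 nM.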

Compound 4, half-maximal cytotoxic concentration: 2300 nM
Estimate against measurement, compound 4: 5.2-fold (0.72 log units) above, outside the stated range (below it).
By their numbers in this assay, from the lowest: compound 4; then compounds 1 and 2 (each within the scatter of the next). At a limit, above all of these: compound 3.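

In this assay, leaving 3-carboxyazetidin-1-yl for 2,6-dimethylmorpholin-4-yl gives an at least 86-fold lower number from compound 3 to compound 4 (1.93 log units; beyond the scatter), so a large step now appears with a second replacement group at this place on the saturated chain carbon bound to an aromatic carbon. The replacement groups themselves also differ: 2,6-dimethylmorpholin-4-yl in place of 3-(dimethylamino)pyrrolidin-1-yl gives a 2.5-fold lower number from compound 1 to compound 4 (0.40 log units; beyond the scatter), a modest step, so less compound is tolerated with this group and the place responds to more than the presence or absence of 3-carboxyazetidin-1-yl. The value of compound 3 is a limit of the assay and not a number, so the large step from it gives only a minimum size: the limit of > 200000 nM in this assay, at which 1 of the 4 values shown sits.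

The compounds shown do not separate the carboxylic acid from the four-membered ring that carries it; an azetidine without the acid, or a carboxylic acid on a six-membered ring, would show which part goes with the high tolerance. A morpholine without the two methyl groups would likewise show whether those methyl groups play any part in the lower number of compound 4.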